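The source may hold more compounds than are shown below. What is called first, only, known or untested is meant among the compounds shown, and "the series" means these compounds.

Measured in an in vitro ADME assay on microsomes from liver (Homo sapiens) for metabolic stability, tested at 1 uM; a lower number here means slower removal, a higher number faster removal of the compound:
compound 1 `CNC(=O)c1cc(N)c(Nc2ccc(C#N)cc2)cc1Oc1c(C)cc(CCC#N)cc1C` gives 120 mL.min-1.g-1
compound 2 `Cc1cc(CCC#N)cc(C)c1Oc1cc(Nc2ccc(C#N)cc2)c(N)cc1C(F)(F)F` gives 120 mL.min-1.g-1
compound 3 `COC(=O)c1cc(N)c(Nc2ccc(C#N)cc2)cc1Oc1c(C)cc(CCC#N)cc1C` gives 40 mL.min-1.g-1

Compound 1 shares the top number of the three with compound 2, and only compound 3 sits lower. Compound 4 `Cc1cc(CCC#N)cc(C)c1Oc1cc(Nc2ccc(C#N)cc2)c(N)cc1C(N)=O` differs from compound 1 by hydrogen in place of methyl on an amide-type nitrogen, which turns methylcarbamoyl to carbamoyl. For the measured compounds named here, no measured step changes this methyl alone. Going by the values given here, two steps bear on it: no change at the digits printed from compound 1 to compound 2 (within the scatter) with trifluoromethyl in place of methylcarbamoyl, and a 3.0-fold lower number from compound 1 to compound 3 (0.48 log units; beyond the scatter) with methoxy in place of methylamino. A small move towards a lower number in this assay is therefore expected, probably within the scatter. The expected step is a 1.3-fold lower number from compound 1 to compound 4 (0.12 log units; within the scatter). For compound 4 the estimated value is 90 mL.min-1.g-1, with an expected range of 40 mL.min-1.g-1 to 170 mL.min-1.g-1.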

Compound 4, intrinsic clearance in microsomes: 160 mL.min-1.g-1
Compound 4: middle estimate off by 1.8-fold (0.25 log units), on the low side; measured number inside the range.
By their numbers in this assay, from the lowest: compound 3; then compounds 1, 2 and 4 (each within the scatter of the next).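

In this assay, losing the methyl from the amide-type nitrogen has no effect beyond the scatter (a 1.3-fold higher number from compound 1 to compound 4 (0.12 log units; within the scatter)), so this methyl is not needed for the level seen with compound 1. Carbamoyl also stays level with trifluoromethyl on the aromatic carbon (a 1.3-fold higher number from compound 2 to compound 4 (0.12 log units; within the scatter)), while the step from the ester is clear (a 4.0-fold higher number from compound 3 to compound 4 (0.60 log units; beyond the scatter)), leaving methoxycarbonyl alone at the lower number among these four compounds. The data offer no measured cause for this gap.

On these data alone, whether a carboxylic acid or a dimethylcarbamoyl group on this aromatic carbon would fall with compound 3 or with compounds 1, 2 and 4 remains open.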